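The compounds below may be only part of what the source reports. "The series", "measured", "known", "first", "only" and "open" are said of these compounds alone.

Working notes on the series. The shared core carries a 4-methoxyphenyl group on the ring carbon next to one ring nitrogen, while the saturated ring carbon next to the other nitrogen bears a varied aryl group, and the ring nitrogen carries a carbonyl-linked group. Compound 1 is `COc1ccc(C2=NN(C(=O)C3COc4ccccc4O3)C(c3cccc(F)c3)C2)cc1` and in a functional assay on WM 266-4 cells (Homo sapiens) for inhibition, read by MTT assay, with a stated time of 24 h (a lower number here means a stronger inhibitor of growth, a higher number a weaker inhibitor of growth), compound 1 gives 6720 nM. Compound 3 is `COc1ccc(C2=NN(C(=O)C3COc4ccccc4O3)C(c3ccccc3F)C2)cc1`; in this assay compound 3 gives 5720 nM. Compound 2 is `COc1ccc(C2=NN(C(=O)c3ccc4c(c3)OCCO4)C(c3ccc(OC)cc3)C2)cc1` and in this assay compound 2 gives 9890 nM; it carries the 4-methoxyphenyl group on the saturated ring carbon, with a different carbonyl-linked group.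

Compound 3 gives the lowest of the three numbers, but its gaps to compound 1 and to compound 2 both lie within the scatter, so no ranking among the three is claimed. For the measured compounds named here, the only step measured in one place is a 1.2-fold lower number from compound 1 to compound 3 (0.07 log units; within the scatter), within the scatter.

Compound 4 is `COc1ccc(C2=NN(C(=O)C3COc4ccccc4O3)C(c3ccc(OC)cc3)C2)cc1`. It differs from compound 3 as follows: 4-methoxyphenyl in place of 2-fluorophenyl on a saturated ring carbon. Going by the values given here, no measured step covers this exchange directly; the pair of compound 2 and compound 3 shares the 4-methoxyphenyl aspect but differs also elsewhere, so only their two values can be compared. Given those values, a step of a 1.3-fold higher number from compound 3 to compound 4 (0.12 log units; within the scatter) is expected, within or near the scatter, and compound 4 is estimated at 7500 nM, with a range from 3000 nM to 20000 nM.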

Compound 4, concentration for 50% growth inhibition: 11000 nM
Estimate against measurement, compound 4: 1.5-fold (0.17 log units) below; low and high end bracket the measured number.
By their numbers in this assay, from the lowest: compounds 3, 1, 2 and 4 (each within the scatter of the next).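

On the saturated ring carbon, with the carbonyl-linked group held constant, this assay gives a 1.9-fold higher number from compound 3 to compound 4 (0.28 log units; within the scatter) for 4-methoxyphenyl in place of 2-fluorophenyl and a 1.6-fold higher number from compound 1 to compound 4 (0.21 log units; within the scatter) for 4-methoxyphenyl in place of 3-fluorophenyl, so the exchange of a fluorophenyl group for 4-methoxyphenyl stays within the scatter for both fluorine placements. The carbonyl-linked group now also has a step in one place, since 2,3-dihydro-1,4-benzodioxin-2-yl in place of 2,3-dihydro-1,4-benzodioxin-6-yl on a carbonyl carbon gives a 1.1-fold higher number from compound 2 to compound 4 (0.05 log units; within the scatter) and so no separation between these two groups can be read with 4-methoxyphenyl on the saturated ring carbon. No measurement at hand offers an explanation for any of these steps.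

From the compounds shown here alone, whether an amine or a carboxylic acid on the aryl group at this position, or a longer chain in place of that aryl group, would move the number beyond the scatter stays open. Going by these compounds, the two carbonyl-linked groups are also compared only with 4-methoxyphenyl on the saturated ring carbon, so their relation with 2-fluorophenyl or 3-fluorophenyl there remains open.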